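The source may hold more compounds than are shown below. What is called first, only, known or untested is meant among the compounds shown, and "the series" means these compounds.

Measured compounds in a functional assay on cells (Cancer cell lines, Homo sapiens) for inhibition, read by MTT assay, with a stated time of 48 h; on this read-out higher numbers stand for weaker inhibition and lower numbers for stronger inhibition:
- compound 1 `O=C(/C=C/c1ccc(F)cc1)NNC(=O)c1ccc2c(c1)OCCO2`: 990 nM
- compound 2 `Cc1ccccc1/C=C/C(=O)NNC(=O)c1ccc2c(c1)OCCO2`: 7710 nM

Among the compounds with values here, compound 2 holds the highest of the two numbers so far; its nearest neighbour is compound 1, and the change a 7.8-fold higher number from compound 1 to compound 2 (0.89 log units; beyond the scatter) separates them. The next member, compound 3 `O=C(/C=C/c1ccccc1Cl)NNC(=O)c1ccc2c(c1)OCCO2`, is drawn from compound 2 by one replacement: chloro in place of methyl on an aromatic carbon. Within the data shown here, no measured pair shows chloro against methyl at this ring position, so the one recorded step, from compound 1 to compound 2, bears on the new compound only loosely: it shows that the substituent pattern on this ring can move the number well beyond the scatter, but it exchanges both the substituent and its ring position at once and so does not fix the direction for compound 3. In this assay compound 3 is expected to land near 4500 nM, with the plausible range 1500 nM to 13000 nM. The estimated step is a 1.7-fold lower number from compound 2 to compound 3 (0.23 log units; within the scatter), a small gain that is expected to stay within or close to the scatter.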

Compound 3, half-maximal inhibitory concentration: 4880 nM
Compound 3: the middle estimate sits 1.1-fold (0.04 log units) below what was measured; the range from low to high includes it.
By their numbers in this assay, from the lowest: compound 1; then compounds 3 and 2 (each within the scatter of the next).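

In this assay, chloro in place of methyl at this position, ortho to a large group, gives a 1.6-fold lower number from compound 2 to compound 3 (0.20 log units; within the scatter) and so leaves the two compounds indistinguishable on this read-out. The second new comparison, a 4.9-fold higher number from compound 1 to compound 3 (0.69 log units; beyond the scatter) with 2-chlorophenyl in place of 4-fluorophenyl, shows that the gap first seen with 2-methylphenyl is not confined to that one group, since both compounds carrying these replacements stand beyond the scatter from compound 1. No measured information on any property of these groups bears on this result, so the numbers describe the size of the steps and give no reason for them.

Each step from compound 1 exchanges the substituent and its ring position at once, leaving open which of the two carries the gap. Also open, going by these compounds, is whether the flat reading between methyl and chloro at this position extends to a methoxy group or an amine in the same place.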